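A Sulfur Linker Replaces an Oxygen Linker on the Core

A few compounds are considered here, and "the series" means these few. Any claim that something is new, unique, unknown or untested is made for them only; others in the source may bear on it.

Measured so far:
compound 1, `Nc1cc(N)c2nc(-c3ccccc3)c(NCc3ccc(Cl)c(Cl)c3)nc2c1`, gives 67600 nM
compound 2, `Nc1cc(N)c2nc(-c3ccccc3)c(Oc3ccc(F)cc3)nc2c1`, gives 69200 nM
compound 3, `COc1ccc(CNc2nc3cc(N)cc(N)c3nc2-c2ccccc2)cc1`, gives 58900 nM

These three compounds share a core and were tested in a functional assay on UACC-62 cells (Homo sapiens) for inhibition, read by sulforhodamine B assay, with a stated time of 48 h; a higher number here means that more compound is tolerated, a lower number that less compound is tolerated. Compound 2 shows the highest number of the three, yet its gap to compound 1 and to compound 3 lies within the scatter of repeated measurements, so no real order among them can be read off.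

Compound 4, `COc1ccc(Sc2nc3cc(N)cc(N)c3nc2-c2ccccc2)cc1`, has not yet been measured. It differs from compound 2 in one place: (4-methoxyphenyl)sulfanyl in place of 4-fluorophenoxy on an aromatic carbon.

Only one measured step exists among these compounds: a 1.1-fold lower number from compound 1 to compound 3 (0.06 log units; within the scatter). That step concerns a different position and a different kind of exchange, so it bears on the present change only loosely, but it shows that a substituent swap on this core left this assay essentially unchanged. For the measured compounds named here, no measured step compares an oxygen linker with a sulfur linker here.

Compound 4 is therefore expected to give 65000 nM, with a range from 30000 nM to 140000 nM. This estimate means a step of a 1.1-fold lower number from compound 2 to compound 4 (0.03 log units; within the scatter), which is expected to remain within the scatter.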

Compound 4, concentration lethal to 50% of the cells: < 100000 nM
Compound 4 gave a limit, no number; the forecaster's own chance of this, stated with the estimate: 10%; the middle value is on the limit's open side.
By their numbers in this assay, from the lowest: compounds 3, 1 and 2 (each within the scatter of the next).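

In this assay compound 4 gives < 100000 nM, which is a limit and not a number. For the compounds shown here, no step between compound 2 and compound 4 can be read from it. The compounds shown leave open whether (4-methoxyphenyl)sulfanyl in place of 4-fluorophenoxy on an aromatic carbon changes the number in this assay at all.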